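A pyrazole replaces the phenyl group of compound 3

The source may report more compounds than this note shows. Statements on the series, on what has been measured and on what is new or still open speak of the compounds shown alone.

In an ADME assay on HEp-2 cells (Homo sapiens) for cytotoxicity (a lower number here means that less compound is tolerated, a higher number that more compound is tolerated), compound 1 (`Cc1cc(C)cc(NC(=O)[C@@H]2CCCN2S(=O)(=O)c2cccc3cccnc23)c1`) gives 31300 nM. Compound 2 (`O=C(Nc1ccc(Cl)cc1Cl)[C@@H]1CCCN1S(=O)(=O)c1cccc2cccnc12`) gives > 50000 nM, which is a limit of the assay and not a number. Among the compounds with values here, compound 3 (`Cc1ccc(C(C)C)cc1NC(=O)[C@@H]1CCCN1S(=O)(=O)c1cccc2cccnc12`) gives 9700 nM, the lowest number so far. Compound 4 (`Cc1cc(NC(=O)[C@@H]2CCCN2S(=O)(=O)c2cccc3cccnc23)n(C(C)(C)C)n1`) differs from it on an amide-type nitrogen: 3-methyl-1-(tert-butyl)-1H-pyrazol-5-yl in place of 5-isopropyl-2-methylphenyl on an amide-type nitrogen. All three measured steps change this same group. Two of them, a 3.2-fold lower number from compound 1 to compound 3 (0.51 log units; beyond the scatter) and an at least 5.1-fold lower number from compound 2 to compound 3 (0.71 log units; beyond the scatter), lie beyond the scatter, while an at least 1.5-fold higher number from compound 1 to compound 2 (0.20 log units; that floor lies within the scatter) has its floor within it. Both larger steps lead down, so leaving this group is expected to raise the number modestly in this assay, an estimated 2.3-fold higher number from compound 3 to compound 4 (0.36 log units; beyond the scatter). Compound 4 is expected at 22000 nM, within 8000 nM to 50000 nM.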

Compound 4, half-maximal cytotoxic concentration: > 50000 nM
Compound 4: a limit, no number; the forecaster's own chance of this, stated with the estimate: 20%; at least 2.2-fold (0.35 log units) between middle value and limit.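

A pyrazole, the only ring shown in this place that is not a phenyl, gives an at least 5.1-fold higher number from compound 3 to compound 4 (0.71 log units; beyond the scatter) in this assay. Against the 3,5-dimethylphenyl group the change gives an at least 1.5-fold higher number from compound 1 to compound 4 (0.20 log units; that floor lies within the scatter), so this comparison does not separate the two groups. Compound 4 sits at a limit of the assay and not at a number, as does compound 2, so the step between them cannot be read: the limit of > 50000 nM in this assay, at which 2 of the 4 values shown sit.

Going by these compounds, it stays open whether the tert-butyl or the methyl on the pyrazole matters for this result. Also open, on these data alone, is what a pyridine ring on the amide-type nitrogen would give.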